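A few compounds are considered here, and "the series" means these few. Any claim that something is new, unique, unknown or untested is made for them only; others in the source may bear on it.

In an ADME assay on P388 cells (Mus musculus) for cytotoxicity (on this read-out higher numbers stand for weaker inhibition and lower numbers for stronger inhibition), compound 1 (`NC(=O)c1csc([C@@H]2O[C@H](COP(=O)(O)O)[C@@H](O)[C@H]2O)n1`) gives 10 uM and compound 2 (`NC(=O)c1c[se]c([C@@H]2O[C@H](COP(=O)(O)O)[C@@H](O)[C@H]2O)n1`) gives 1.4 uM. Compound 3 (`NC(=O)c1ncn(C2O[C@H](COP(=O)(O)OP(=O)(O)OC[C@H]3OC(n4cnc5c(N)ncnc54)[C@H](O)[C@@H]3O)[C@H](O)[C@@H]2O)n1`) gives 40 uM, the highest number of the three and thus the weakest inhibition, beyond the scatter from both others. Compound 4 (`NC(=O)c1ncn(C2O[C@H](COP(=O)(O)OP(=O)(O)OC[C@H]3OC(n4cnc5c(N)ncnc54)[C@H](O)[C@@H]3O)[C@H](O)[C@@H]2O)c1N`) has not yet been measured. It keeps the rest of compound 3, but on a saturated ring carbon 5-amino-4-carbamoyl-1H-imidazol-1-yl stands in place of 3-carbamoyl-1H-1,2,4-triazol-1-yl (5-amino-4-carbamoyl-1H-imidazol-1-yl in place of 3-carbamoyl-1H-1,2,4-triazol-1-yl on a saturated ring carbon). For the measured compounds named here, no measured pair shows this change, so the expectation in this assay is loose: no step beyond the scatter. The expected step is a 1.3-fold higher number from compound 3 to compound 4 (0.10 log units; within the scatter). For compound 4 the estimated value is 50 uM, with an expected range from 15 uM to 170 uM.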

Compound 4, concentration for 50% inhibition: 78 uM
The estimate for compound 4 lay 1.6-fold (0.19 log units) below the measured number; the range from low to high includes it.
By their numbers in this assay, from the lowest: compound 2; then compound 1; then compounds 3 and 4 (each within the scatter of the next).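

In this assay, 5-amino-4-carbamoyl-1H-imidazol-1-yl in place of 3-carbamoyl-1H-1,2,4-triazol-1-yl on a saturated ring carbon gives a 2.0-fold higher number from compound 3 to compound 4 (0.29 log units; within the scatter). For the compounds shown here, this is the first pair that differs in one place, and it shows that this exchange at this position brings no step beyond the scatter. No measurement at hand accounts for this outcome.

From the compounds shown here alone, it remains open what a carboxylic acid in place of the carbamoyl group would give at this position. Going by these compounds, it is also open whether the same exchange would behave alike on the core of compound 1.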